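Moving a chlorine around the benzyl ring of a nucleoside

The compounds below may be only part of what the source reports. "The series", "measured", "known", "first", "only" and "open" are said of these compounds alone.

Compound 1: `Nc1ncnc2c1nc(NCc1ccccc1Cl)n2[C@@H]1O[C@H](CO)[C@@H](O)[C@H]1O` gives 5700 nM
Compound 2: `Nc1ncnc2c1nc(NCc1ccccc1-c1ccccc1)n2[C@@H]1O[C@H](CO)[C@@H](O)[C@H]1O` gives > 100000 nM

Within the data shown here, in an assay on COS-7 cells for inhibition of sodium/nucleoside cotransporter 2 (Homo sapiens), read by scintillation counting, in the presence of a further agent that is not named here (on this read-out higher numbers stand for weaker inhibition and lower numbers for stronger inhibition), compound 1 gives 5700 nM, the only plain number among the two values shown. Compound 2 reaches only a limit of this assay, > 100000 nM, so its true value is not known. The step of an at least 17-fold higher number from compound 1 to compound 2 (1.24 log units; beyond the scatter) is large, resting on (the limit of > 100000 nM in this assay, at which 1 of the 2 values shown sits).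

Compound 3, `Nc1ncnc2c1nc(NCc1ccc(Cl)cc1)n2[C@@H]1O[C@H](CO)[C@@H](O)[C@H]1O`, has not yet been measured in this assay. It differs from compound 1 by 4-chlorophenyl in place of 2-chlorophenyl on a saturated chain carbon bound to a nitrogen on an aromatic ring. Among the measured compounds shown here, only one measured step touches this part of the structure, and it swapped the chloro for a much larger phenyl rather than moving the same chloro. That step weakened inhibition sharply, so altering this ring matters, but moving the chlorine is a smaller change. For compound 3 the expected step is a 1.8-fold higher number from compound 1 to compound 3 (0.24 log units; within the scatter), a modest weakening within a wide range. Compound 3 is therefore estimated at 10000 nM, between 2500 nM and 50000 nM.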

Compound 3, half-maximal inhibitory concentration: 11000 nM
Estimate against measurement, compound 3: 1.1-fold (0.04 log units) below; the measured number falls inside the stated range.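

In this assay moving the chlorine, from 2-chlorophenyl to 4-chlorophenyl on a saturated chain carbon bound to a nitrogen on an aromatic ring, gives a 1.9-fold higher number from compound 1 to compound 3 (0.29 log units; within the scatter) and nothing more. These two placings of the same chlorine therefore cannot be told apart on this read-out, even though the atoms are joined differently. The one large step at this part of the structure remains the swap of chloro for phenyl, and its size is known only as a bound, resting on this: the limit of > 100000 nM in this assay, at which 1 of the 3 values shown sits.

As far as these compounds go, it remains open how a plain benzyl group with no chlorine would compare with these two compounds. Also open, from the compounds shown here alone, is whether a methoxy group or a fluorine in place of the chlorine would keep inhibition in the same range.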